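A few compounds are considered here, and "the series" means these few. Any claim that something is new, unique, unknown or untested is made for them only; others in the source may bear on it.

Compound 1 `C#CCSc1nnc(-c2cc(OC)c(OC)c(OC)c2)n1N1C(=O)c2ccccc2C1=O` — in a functional assay on PC-3M cells (Homo sapiens) for cytotoxicity, read by MTT assay, with a stated time of 48 h (a lower number here means a stronger inhibitor, a higher number a weaker inhibitor), compound 1 gives > 200000 nM, which is a limit of the assay rather than a number.
Compound 2 `COc1cc(-c2nnc(SCC(=O)c3ccccc3)n2N2C(=O)c3ccccc3C2=O)cc(OC)c1OC` — in this assay compound 2 gives > 200000 nM, again a limit.
Compound 3 `COc1cc(-c2nnc(SCC(=O)c3ccc(F)cc3)n2N2C(=O)c3ccccc3C2=O)cc(OC)c1OC` — in this assay compound 3 gives > 200000 nM, also a limit.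

Compound 3 therefore stands at the same limit as the other two, and there is no number that would set it apart from either of them. Among the compounds with values here, this is the whole picture of the series so far, since the limit of > 200000 nM in this assay, at which 3 of the 3 values shown sit: none of the three compounds gave a readable concentration.

Compound 4 `COc1cc(-c2nnc(SCC(=O)c3ccc(Br)cc3)n2N2C(=O)c3ccccc3C2=O)cc(OC)c1OC` differs from compound 3 by bromo in place of fluoro on an aromatic carbon, so that the (4-fluorophenyl)carbonyl becomes a (4-bromophenyl)carbonyl. Within the data shown here, the steps that bear on it are a step that the two limits leave unreadable from compound 2 to compound 3 and a step that the two limits leave unreadable from compound 1 to compound 3, and both remain unreadable. The values on both sides of each of them sit at the limit. Nothing therefore supports an expectation of a step beyond the scatter in this assay in either direction. For compound 4 the estimated value is 300000 nM, from 100000 nM to 1000000 nM, and the expected step is a step that the limit leaves unreadable from compound 3 to compound 4, with the outcome most likely again reported only as a limit.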

Compound 4, half-maximal inhibitory concentration: 22600 nM
Beside the measured number, compound 4's estimate is 13-fold (1.12 log units) above it, and the stated range ends above it.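

Within the data shown here, the bromo group is the first change at this para carbon of the six-membered aromatic ring to bring a readable concentration: bromo in place of fluoro gives an at least 8.8-fold lower number from compound 3 to compound 4 (0.94 log units; beyond the scatter), and bromo in place of hydrogen gives an at least 8.8-fold lower number from compound 2 to compound 4 (0.94 log units; beyond the scatter). Against the chain with the ethynyl end, the (4-bromophenyl)carbonyl group gives an at least 8.8-fold lower number from compound 1 to compound 4 (0.94 log units; beyond the scatter). Each step starts from a limit, so it fixes only a smallest size, and compound 4 is the one compound shown that leaves the ceiling of this assay: the limit of > 200000 nM in this assay, at which 3 of the 4 values shown sit.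

As far as these compounds go, the true size of these steps remains open, as does any order among the compounds at the limit. The compounds shown carry only hydrogen, fluoro or bromo at this carbon, so it also remains open whether chloro, iodo or methoxy there would give a readable value.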